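This account rests on a few compounds, and the source may have more. Where it says the series, first, only, none or still open, it means among the compounds named here.

Working notes on the urea series in a functional assay on NCI-H460 cells (Homo sapiens) for antiproliferative activity, read by MTT assay, with a stated time of 72 h; a higher number here means a weaker inhibitor, a lower number a stronger inhibitor.

The shared core is seen in compound 1 `Cn1cnnc1-c1cc(Oc2ccc(NC(=O)Nc3cccc(C(F)(F)F)c3)cc2F)ccn1`, which in this assay gives 1270 nM. Compound 2 `CN(C)CCn1cnnc1-c1cc(Oc2ccc(NC(=O)Nc3cccc(C(F)(F)F)c3)cc2F)ccn1` gives 2150 nM in this assay, and compound 3 `CN(C)CCCn1cnnc1-c1cc(Oc2ccc(NC(=O)Nc3cccc(C(F)(F)F)c3)cc2F)ccn1` gives 1790 nM. The three measured steps all concern the chain on the saturated carbon bound to an aromatic nitrogen: a 1.7-fold higher number from compound 1 to compound 2 (0.23 log units; within the scatter), a 1.4-fold higher number from compound 1 to compound 3 (0.15 log units; within the scatter) and a 1.2-fold lower number from compound 2 to compound 3 (0.08 log units; within the scatter). Compound 3 therefore stands second highest of the three numbers, nearest to compound 2 and furthest from compound 1, with all three within the scatter of one another; no ordering among them can be claimed.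

Compound 4 `CN(C)CCCn1cnnc1-c1cc(Oc2ccc(NC(=O)Nc3ccc(F)c(Cl)c3)cc2F)ccn1` differs from compound 3 by 3-chloro-4-fluorophenyl in place of 3-(trifluoromethyl)phenyl on an amide-type nitrogen. Among the compounds with values here, none of the measured steps touch the aryl group on the amide-type nitrogen; all three vary the other end of the molecule and none moved beyond the scatter, so they give no direct read on this change. The expectation for compound 4 therefore rests on compound 3 alone, and the expected step of a 1.0-fold higher number from compound 3 to compound 4 (0.00 log units; within the scatter) is one of no clear direction, with a range widened to reflect the absence of a precedent. Compound 4 is estimated at 1800 nM in this assay, expected to lie between 600 nM and 5500 nM.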

Compound 4, half-maximal inhibitory concentration: 1270 nM
Compound 4: the middle estimate sits 1.4-fold (0.15 log units) above what was measured, and the stated range covers the measured number.
By their numbers in this assay, from the lowest: compounds 1, 4, 3 and 2 (each within the scatter of the next).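

In this assay, within the data shown here, the replacement of 3-(trifluoromethyl)phenyl by 3-chloro-4-fluorophenyl on the amide-type nitrogen gives a 1.4-fold lower number from compound 3 to compound 4 (0.15 log units; within the scatter) and is the first measured step at this end of the urea series, so these two aryl groups cannot be told apart in this assay when the other end of the molecule stays as in compound 3. The earlier steps shown here varied only that other end, and this step extends the picture: a change of aryl group, with 10 heavy atoms leaving and 8 entering, also stays within the scatter, although one pair of groups says little about this position as a whole. No evidence bearing on this result is at hand.

On these data alone, it remains open whether an unsubstituted phenyl, a 3-cyanophenyl, a 4-methoxyphenyl or a pyridyl group on the same nitrogen would give a step beyond the scatter. As far as these compounds go, it is also open whether 3-chloro-4-fluorophenyl would read the same on the chains of compound 1 or compound 2, or on a longer chain or one ending in a morpholine.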